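Replacing pyridin-3-yl on the carbonyl carbon of compound 2

The compounds below may be only part of what the source reports. "The series", "measured", "known", "first", "only" and "open" are said of these compounds alone.

Measured so far in an ADME assay on HepG2 cells (Homo sapiens) for cytotoxicity, read by neutral red uptake, with a stated time of 24 h; on this read-out higher numbers stand for weaker inhibition and lower numbers for stronger inhibition:
- compound 1 (`CCCC(=O)Oc1c(C(C)C)cc2c3c1OC(=O)[C@@]31CCCC(C)(C)[C@@H]1CC2`): 56100 nM
- compound 2 (`CC(C)c1cc2c3c(c1OC(=O)c1cccnc1)OC(=O)[C@@]31CCCC(C)(C)[C@@H]1CC2`): 264000 nM

Compound 2 holds the higher of these two numbers. Compound 3 (`CC(C)c1cc2c3c(c1OC(=O)CCCc1c[nH]c4ccccc14)OC(=O)[C@@]31CCCC(C)(C)[C@@H]1CC2`) has 3-(1H-indol-3-yl)propyl in place of pyridin-3-yl on a carbonyl carbon. Within the data shown here, the only measured step bearing on this is a 4.7-fold higher number from compound 1 to compound 2 (0.67 log units; beyond the scatter), which came with pyridin-3-yl replacing propyl. Compound 3 again carries a propyl chain, as compound 1 (56100 nM) does, now ending in indolyl, a group untested here. A lower number is therefore expected, an estimated 2.9-fold lower number from compound 2 to compound 3 (0.47 log units; beyond the scatter) in this assay. For compound 3 the estimate is 90000 nM, with an expected range from 25000 nM to 300000 nM.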

Compound 3, half-maximal inhibitory concentration: 120000 nM
The estimate for compound 3 lay 1.3-fold (0.12 log units) below the measured number; the measured number falls inside the stated range.
By their numbers in this assay, from the lowest: compound 1; then compound 3; then compound 2.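

In this assay the 3-(1H-indol-3-yl)propyl group brings a 2.2-fold lower number from compound 2 to compound 3 (0.34 log units; beyond the scatter) when it replaces pyridin-3-yl on the carbonyl carbon. Placing 1H-indol-3-yl on the saturated chain carbon, three bonds along the chain from a carbonyl carbon, brings a 2.1-fold higher number from compound 1 to compound 3 (0.33 log units; beyond the scatter) and leaves compound 3 between the two earlier compounds, although it carries the largest of the three groups. Nothing available accounts for the size or direction of these steps.

On these data alone, whether the number follows the chain or the indole remains open. A shorter chain ending in 1H-indol-3-yl, or a propyl chain ending in phenyl or an amine, would separate the two.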